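Removing the Methyl from the Core of Compound 1

The source may report more compounds than this note shows. Statements on the series, on what has been measured and on what is new or still open speak of the compounds shown alone.

Compound 1 `Cc1nn(-c2ccccn2)c2cc(-c3ccc(CCC(=O)O)cc3)ccc12` gives 95% in a functional assay on cells for agonist activity at Free fatty acid receptor 1 (Mus musculus), read by FLIPR and calcium flux, with a stated time of 5 min (a higher number here means a larger maximal response, a lower number a smaller maximal response), and stands second highest among the three measured compounds. Compound 3 `Cc1nn(-c2ccccn2)c2cc(-c3ccc(CCC(=O)O)cc3Cl)ccc12` gives 102%, and a number 7 percentage points higher from compound 1 to compound 3 (within the scatter). Compound 2 `Cc1nn(-c2ccccn2)c2cc(-c3ccc(CC(C)(C)C(=O)O)cc3)ccc12` gives 18%, and a number 77 percentage points lower from compound 1 to compound 2 (beyond the scatter). Compound 4 `O=C(O)CCc1ccc(-c2ccc3cnn(-c4ccccn4)c3c2)cc1` has not yet been measured. Compared with compound 1 its difference is hydrogen in place of methyl on an aromatic carbon. Neither measured step touches this place: the step to compound 3 altered an aromatic carbon of the outer phenyl ring and left the response within the scatter, while the step to compound 2 altered the saturated chain bearing the acid and cut the response strongly. For the measured compounds named here, the change in compound 4 sits on the core, away from the acid chain, so a small step is expected rather than a large one, though no measured pair confirms this directly. For compound 4 a maximal response of 85% is estimated, with a range from 55% to 105%. This estimate means an expected a number 10 percentage points lower from compound 1 to compound 4 (within the scatter).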

Compound 4, largest response reached (reported as efficacy), in percent of the reference or control that the assay uses: 106%
Compound 4: the middle estimate sits 21 percentage points below what was measured, outside the stated range (above it).
By their numbers in this assay, from the lowest: compound 2; then compounds 1, 3 and 4 (each within the scatter of the next, the first and the last beyond it).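

In this assay the methyl on this aromatic carbon, two ring bonds from the ring atom bearing the pyridin-2-yl group, is not needed for the maximal response: hydrogen in its place gives a number 11 percentage points higher from compound 1 to compound 4 (beyond the scatter) and the response is kept. For the compounds shown here, this is the first measured change on the shared core, and unlike the change on the acid chain, which gave a number 77 percentage points lower from compound 1 to compound 2 (beyond the scatter), the loss of this one carbon does not cut the response. Nothing available here explains the direction of this step.

The compounds shown leave open whether an ethyl, a methoxy, an amine or a chloro on this same carbon would keep the response. They also leave open how hydrogen at this place would combine with the chloro on the outer phenyl ring of compound 3.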